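The compounds below may be only part of what the source reports. "The series", "measured", "known", "first", "only" and "open" are said of these compounds alone.

Working notes on the series. The shared core of compound 1 `O=C(COc1ccc(Cl)cc1)N1CCN(c2ncnc3sc(F)cc23)CC1` carries hydrogen at the aromatic carbon in question, and in a functional assay on cells (Lymphocyte) (on this read-out lower numbers stand for stronger inhibition and higher numbers for weaker inhibition), compound 1 gives 6350 nM. Compound 2 `CCCCc1nc(N2CCN(C(=O)COc3ccc(Cl)cc3)CC2)c2cc(F)sc2n1` carries butyl there and in this assay gives 1330 nM; the change is a 4.8-fold lower number from compound 1 to compound 2 (0.68 log units; beyond the scatter). Compound 3 `O=C(COc1ccc(Cl)cc1)N1CCN(c2nc(-c3ccccc3)nc3sc(F)cc23)CC1` carries phenyl at the same carbon. In this assay, among the measured compounds shown here, compound 3 reaches only the limit of > 10000 nM, not a number, and it is the one member of the set at the limit of > 10000 nM in this assay, at which 1 of the 3 values shown sits. Against compound 1 that step is an at least 1.5-fold higher number from compound 1 to compound 3 (0.19 log units; that floor lies within the scatter), and against compound 2 it is an at least 7.5-fold higher number from compound 2 to compound 3 (0.87 log units; beyond the scatter).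

Compound 4 `Nc1nc(N2CCN(C(=O)COc3ccc(Cl)cc3)CC2)c2cc(F)sc2n1` differs from compound 3 by amino in place of phenyl on an aromatic carbon. For the measured compounds named here, the bearing steps are the two that introduce phenyl: the one from compound 1 within the scatter at its floor, the one from compound 2 clearly beyond it. Amino is far smaller than phenyl, so the step from compound 3 to compound 4 is expected to run downward, an at least 2.0-fold lower number from compound 3 to compound 4 (0.30 log units; that floor lies within the scatter), landing near the hydrogen analogue rather than the butyl one. For compound 4 an estimate of 5000 nM is expected, with a range from 1500 nM to 15000 nM.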

Compound 4, half-maximal inhibitory concentration: 700 nM
The estimate for compound 4 lay 7.1-fold (0.85 log units) above the measured number; measured number below the stated range.
By their numbers in this assay, from the lowest: compounds 4 and 2 (each within the scatter of the next); then compound 1. At a limit, above all of these: compound 3.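

Among the compounds shown here, at this carbon, between two ring nitrogen atoms, amino with its 1 heavy atom does what the earlier compounds showed only for butyl in this assay, lowering the number against hydrogen: a 9.1-fold lower number from compound 1 to compound 4 (0.96 log units; beyond the scatter). A chain is therefore not required at this position, and the change from butyl to amino stays within the scatter: a 1.9-fold lower number from compound 2 to compound 4 (0.28 log units; within the scatter). The step from phenyl is large, an at least 14-fold lower number from compound 3 to compound 4 (1.15 log units; beyond the scatter), and it is only a floor, compound 3 being the one compound at a limit: the limit of > 10000 nM in this assay, at which 1 of the 4 values shown sits.

The compounds shown do not tell whether the numbers for compound 2 and compound 4 have a common origin, as butyl and amino share little beyond their lower numbers. A methylamino, dimethylamino or methoxy group at this carbon would test whether the amino hydrogens matter.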